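This account rests on a few compounds, and the source may have more. Where it says the series, first, only, none or still open, it means among the compounds named here.

Of the compounds shown here, three have so far been tested in a functional assay on LNCaP cells (Homo sapiens) for antiproliferative activity, read by propidium iodide staining, with a stated time of 96 h; on this read-out lower numbers stand for stronger inhibition and higher numbers for weaker inhibition. Compound 1 (`CC(O)(CSc1cccc(S(F)(F)(F)(F)F)c1)C(=O)Nc1ccc(C#N)cc1C(F)(F)F`) gives 17600 nM, compound 2 (`CC(O)(COc1cccc(S(F)(F)(F)(F)F)c1)C(=O)Nc1cccc(S(F)(F)(F)(F)F)c1`) gives 10900 nM, and compound 3 (`CC(O)(COc1ccc(C(F)(F)F)cc1)C(=O)Nc1cccc(S(F)(F)(F)(F)F)c1`) gives 9600 nM. The number for compound 2 lies within the scatter of those for both compound 3 and compound 1, so it cannot be separated from either.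

Compound 4 (`CC(O)(COc1cccc(OC(F)(F)F)c1)C(=O)Nc1cccc(S(F)(F)(F)(F)F)c1`) has not yet been measured. It keeps the rest of compound 2 and differs in one place: a group of 5 heavy atoms (1 carbon, 1 oxygen, 3 fluorine; no ring) in place of a group of 6 heavy atoms (5 fluorine, 1 sulfur; no ring), on an aromatic carbon. Trifluoromethoxy enters on an aromatic carbon of a six-membered aromatic ring of carbon only, meta to a large group.

Going by the values given here, no pair of measured compounds differs in just one place, so the data offer no direct guide to this exchange. The nearest indication is compound 3, which carries trifluoromethyl on that ring instead and gives 9600 nM, within the scatter of compound 2. In this assay, no change beyond the scatter is therefore expected. The estimated step of a 1.1-fold lower number from compound 2 to compound 4 (0.04 log units; within the scatter) is small and has no firm direction. For compound 4 the expected value is 10000 nM, with an estimated range of 5000 nM to 20000 nM.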

Compound 4, half-maximal inhibitory concentration: 15200 nM
Compound 4: middle estimate off by 1.5-fold (0.18 log units), on the low side; the range from low to high includes it.
By their numbers in this assay, from the lowest: compounds 3, 2, 4 and 1 (each within the scatter of the next).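

In this assay, going by these compounds alone, the exchange of the group of 6 heavy atoms (5 fluorine, 1 sulfur) for trifluoromethoxy, on an aromatic carbon meta to a large group, provides the first step that can be read directly between two compounds, a 1.4-fold higher number from compound 2 to compound 4 (0.14 log units; within the scatter), so this single exchange at this position leaves the read-out unchanged beyond the scatter. The step also shows that the count of hydrogen-bond acceptors can go from 0 to 1 at this position without a separable change in the number, at least for this one pair. No measurement among those shown bears on why the step is this size.

What the compounds leave open is whether this position responds at all, since every group shown here on that ring gives numbers within the scatter of its neighbours, and it remains unknown whether an amine, a carboxylic acid or a longer alkyl chain in the same place would move the number beyond it. On these data alone, it is also open whether the exchange would give the same step with a nitrile on the other aromatic ring of the core.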